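Replacing the dibromopyridinyl amide group with a non-aromatic diazine

The source may report more compounds than this note shows. Statements on the series, on what has been measured and on what is new or still open speak of the compounds shown alone.

Measured compounds:
compound 1 `COc1ccc(C(=O)Nc2cccc(Cl)c2Cl)cc1OC1CCCC1` — > 200000 nM
compound 2 `COc1ccc(C(=O)Nc2ccccc2SC)cc1OC1CCCC1` — 1200 nM
compound 3 `COc1ccc(C(=O)Nc2c(Br)cncc2Br)cc1OC1CCCC1` — 7 nM

In an assay on isolated protein for inhibition of phosphodiesterase 4A (Sus scrofa) (a higher number here means a weaker inhibitor, a lower number a stronger inhibitor), compound 1 gives only a limit, > 200000 nM (the limit of > 200000 nM in this assay, at which 1 of the 3 values shown sits). Compound 2 gives 1200 nM and compound 3 gives 7 nM, the lowest number shown; the nearest is a 170-fold lower number from compound 2 to compound 3 (2.23 log units; beyond the scatter), and an at least 28000-fold lower number from compound 1 to compound 3 (4.45 log units; beyond the scatter). Compound 4 `COc1ccc(C(=O)NN2C(Cl)=NC=CC2Cl)cc1OC1CCCC1` differs from compound 3 by a group of 8 heavy atoms (4 carbon, 2 nitrogen, 2 chlorine; one six-membered non-aromatic ring with 2 hetero atoms) in place of a group of 8 heavy atoms (5 carbon, 1 nitrogen, 2 bromine; one six-membered aromatic ring with 1 hetero atom), on an amide-type nitrogen. Among the compounds with values here, none of the measured steps changes this group in the same way, but an at least 160-fold lower number from compound 1 to compound 2 (2.22 log units; beyond the scatter), an at least 28000-fold lower number from compound 1 to compound 3 (4.45 log units; beyond the scatter) and a 170-fold lower number from compound 2 to compound 3 (2.23 log units; beyond the scatter) were all large, so the group on the amide-type nitrogen governs this assay strongly. Compound 4 is therefore expected to give a higher number, a 43-fold higher number from compound 3 to compound 4 (1.63 log units; beyond the scatter), with an estimate of 300 nM and a range from 30 nM to 5000 nM.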

Compound 4, half-maximal inhibitory concentration: 400 nM
Compound 4: the middle estimate sits 1.3-fold (0.12 log units) below what was measured; the range from low to high includes it.
By their numbers in this assay, from the lowest: compound 3; then compound 4; then compound 2. At a limit, above all of these: compound 1.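

Compound 4 shows that in this assay the amide-type nitrogen accepts a six-membered non-aromatic ring, although this ring does not match the 3,5-dibromopyridin-4-yl group, with a 57-fold higher number from compound 3 to compound 4 (1.76 log units; beyond the scatter). The same ring gives a modest gain over the 2-(methylsulfanyl)phenyl group, with a 3.0-fold lower number from compound 2 to compound 4 (0.48 log units; beyond the scatter), and a large one over the 2,3-dichlorophenyl group, with an at least 500-fold lower number from compound 1 to compound 4 (2.69 log units; beyond the scatter). That last step rests on a limit for compound 1: the limit of > 200000 nM in this assay, at which 1 of the 4 values shown sits.

The compounds shown leave open whether the chlorines or the ring nitrogens of compound 4 matter more. They also leave open how a methyl or an amine in place of either chlorine would read.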